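A few compounds are considered here, and "the series" means these few. Any claim that something is new, unique, unknown or untested is made for them only; others in the source may bear on it.

Of the compounds shown here, two built on the same core have been tested in an ADME assay on cells (Homo sapiens) for cytotoxicity, read by resazurin assay, with a stated time of 5 days; a lower number here means that less compound is tolerated, a higher number that more compound is tolerated. Compound 1 `COc1ccc(-c2nc(/C=C\c3cccc(Cl)c3)nc3ccsc23)cn1` gives a half-maximal cytotoxic concentration of 53000 nM. Compound 2 `COc1ccc(-c2nc(CSc3cccc(Cl)c3Cl)nc3ccsc23)cn1` is recorded as > 50000 nM, which is a limit of the assay and not a number. Compound 2 therefore has no exact position and stands at the limit of > 50000 nM in this assay, at which 1 of the 2 values shown sits.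

Compound 3 `COc1ccc(-c2nc(CC(O)c3cccc(Cl)c3)nc3ccsc23)cn1` differs from compound 2 by having (3-chlorophenyl)(hydroxy)methyl in place of (2,3-dichlorophenyl)sulfanyl on a saturated chain carbon bound to an aromatic carbon. For the measured compounds named here, no measured pair of compounds shows what a change of this kind does in this assay, so the expectation rests only on the general level of the series. Going by the values given here, that level is set by compound 1 at 53000 nM, the only exact value available. No shift beyond the usual scatter is expected in either direction, and the assay may again report only a limit. The expected change, an at least 1.1-fold lower number from compound 2 to compound 3 (0.04 log units; that floor lies within the scatter), is therefore small. For compound 3 the estimated value is 45000 nM, with an expected range of 20000 nM to 90000 nM.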

Compound 3, half-maximal cytotoxic concentration: 31000 nM
For compound 3 the middle estimate is 1.5-fold (0.16 log units) above the measured one, within the range that was stated.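

For the compounds shown here, on the saturated chain carbon bound to an aromatic carbon, putting (3-chlorophenyl)(hydroxy)methyl in place of (2,3-dichlorophenyl)sulfanyl gives the first step that can be read in this assay, and compound 3 also gives this position its first exact value: an at least 1.6-fold lower number from compound 2 to compound 3 (0.20 log units; that floor lies within the scatter). Compound 2 is recorded at > 50000 nM, which is a limit of the assay and not a number. The step therefore has a floor but no upper end, and since that floor lies within the usual scatter, the swap may matter little or a good deal more, because one end of the step rests on a limit: the limit of > 50000 nM in this assay, at which 1 of the 3 values shown sits.

The swap changes several things at once, as the sulfur, one chlorine and the hydroxy-bearing carbon all differ, so the compounds shown cannot tell which of these carries the step. Also open, going by these compounds, is how the number would respond to an amine or a carboxylic acid on the same saturated chain carbon, or to a longer chain carrying the 3-chlorophenyl ring.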